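From 2-fluorophenyl to 4-chlorophenyl near an assay limit

This account rests on a few compounds, and the source may have more. Where it says the series, first, only, none or still open, it means among the compounds named here.

Of the compounds shown here, three have been tested in an ADME assay on MT4 cells (Homo sapiens) for cytotoxicity, read by MTT assay, with a stated time of 5 days; on this read-out lower numbers stand for higher toxicity in this test and higher numbers for lower toxicity in this test. Compound 1 (`N#Cc1ccc(Nc2nccc(OCC(=O)Nc3ccc(Cl)cc3)n2)cc1`) gives 162000 nM, a true number. Compound 2 (`Cc1cnc(Nc2ccc(C#N)cc2)nc1OCC(=O)Nc1ccc(F)cc1`) gives > 331000 nM, which is a limit. Compound 3 (`Cc1cnc(Nc2ccc(C#N)cc2)nc1OCC(=O)Nc1ccccc1F`) gives > 331000 nM, which is also a limit, so its true value cannot be read.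

Compound 4 (`Cc1cnc(Nc2ccc(C#N)cc2)nc1OCC(=O)Nc1ccc(Cl)cc1`) has not yet been measured. It differs from compound 3 by one change: 4-chlorophenyl in place of 2-fluorophenyl on an amide-type nitrogen.

Within the data shown here, the only measured step of this kind is a step that the two limits leave unreadable from compound 2 to compound 3, so it offers no size to carry over. The nearest guide is compound 1 at 162000 nM, which carries the same 4-chlorophenyl group, although its core is not identical to that of compound 4. This single value points towards a lower number, meaning higher toxicity in this test, but only weakly. The expected size is an at least 1.5-fold lower number from compound 3 to compound 4 (0.17 log units; that floor lies within the scatter), and this is a rough estimate. Compound 4 is estimated at 220000 nM, with an expected range of 90000 nM to 400000 nM.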

Compound 4, half-maximal cytotoxic concentration: > 317000 nM
Compound 4 ended at the assay's limit; the forecaster's own chance of this, stated with the estimate: 40%; middle value at least 1.4-fold (0.15 log units) from the limit.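

Compound 4 gives only a limit in this assay, not a true number: the limit of > 317000 nM in this assay, at which 1 of the 4 values shown sits. Among these compounds, the one readable change, methyl in place of hydrogen on an aromatic carbon, is an at least 1.9-fold higher number from compound 1 to compound 4 (0.29 log units; that floor lies within the scatter), so the methyl may or may not make a real difference, although the true step could be larger than this floor. With that methyl present, 4-chlorophenyl on the amide-type nitrogen joins 2-fluorophenyl and 4-fluorophenyl at limits, so the steps among compound 2, compound 3 and compound 4 cannot be read.

From the compounds shown here alone, the true values of these three compounds remain open, and so does any ranking of their groups. Also open, going by these compounds, is how a phenyl group carrying an amine or a carboxylic acid would read on the same nitrogen.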